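Removing the 3-Bromophenyl Group: What to Expect

A few compounds are considered here, and "the series" means these few. Any claim that something is new, unique, unknown or untested is made for them only; others in the source may bear on it.

Of the compounds shown here, three sharing one core have been measured in a functional assay on SGC-7901 cells (Homo sapiens) for antiproliferative activity, read by sulforhodamine B assay, with a stated time of 72 h; a lower number here means a stronger inhibitor, a higher number a weaker inhibitor. Compound 1 `CN(C)C(=S)N/N=C/c1ccc2ccccc2n1` gives 30 nM. Compound 2 `S=C(NCc1ccccc1)N/N=C/c1ccc2ccccc2n1` gives 53700 nM. Compound 3 `S=C(N/N=C/c1ccc2ccccc2n1)Nc1cccc(Br)c1` gives 78600 nM, the highest of the three numbers; its nearest neighbour is compound 2, while compound 1 sits far away, with a gap well beyond the usual scatter.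

Compound 4 `NC(=S)N/N=C/c1ccc2ccccc2n1` differs from compound 3 by hydrogen in place of 3-bromophenyl on an amide-type nitrogen. For the measured compounds named here, only one measured step touches this nitrogen: the change from a benzyl group to a 3-bromophenyl group gave a 1.5-fold higher number from compound 2 to compound 3 (0.17 log units; within the scatter), so swapping one bulky group for another changed little. Stripping the nitrogen down to a bare hydrogen has no direct precedent here; compound 1, whose nitrogen carries two methyl groups, shows a far lower number, but no single step links it to compound 3, so its value can only hint that a smaller substituent on this nitrogen need not be unfavourable.

The expected outcome for compound 4 is therefore a 20-fold lower number from compound 3 to compound 4 (1.29 log units; beyond the scatter) in this assay. The estimate for compound 4 is 4000 nM, with a range from 400 nM to 40000 nM.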

Compound 4, half-maximal inhibitory concentration: 32700 nM
Compound 4: middle estimate off by 8.2-fold (0.91 log units), on the low side; the measured number falls inside the stated range.
By their numbers in this assay, from the lowest: compound 1; then compounds 4, 2 and 3 (each within the scatter of the next, the first and the last beyond it).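

In this assay hydrogen in place of 3-bromophenyl on the amide-type nitrogen gives a 2.4-fold lower number from compound 3 to compound 4 (0.38 log units; beyond the scatter) as a modest step, while hydrogen in place of benzyl gives a 1.6-fold lower number from compound 2 to compound 4 (0.22 log units; within the scatter) and leaves these two compounds level. A bare nitrogen therefore stays close to the two compounds carrying large groups, so a small substituent alone does not bring back the low number of compound 1. The decisive change is amino in place of dimethylamino on the thiocarbonyl carbon, which gives a 1100-fold higher number from compound 1 to compound 4 (3.04 log units; beyond the scatter) and shows that the two methyl groups do what hydrogen does not; no measurement shown here offers a reason for this large gap.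

Still open, going by these compounds, is whether a single methyl group on this nitrogen, a longer chain such as ethyl, or a ring such as pyrrolidine or morpholine would keep the low number of compound 1. On these data alone, all four compounds also share one core, and whether dimethylamino would have a similar effect on a different core remains unknown.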